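Swapping a pyridinylmethyl amide for an isobutyl amide

The source may report more compounds than this note shows. Statements on the series, on what has been measured and on what is new or still open speak of the compounds shown alone.

Three compounds from this series have numbers in an assay on isolated protein for inhibition of histone acetyltransferase KAT2B (Homo sapiens), read by fluorescence, with a stated time of 10 min; a lower number here means a stronger inhibitor, a higher number a weaker inhibitor. Compound 1 `O=C(Cn1sc2ccccc2c1=O)NCc1ccccn1` gives 15100 nM there, the second highest of the three. Compound 2 `CCOC(=O)Cn1sc2nc(C)cc(C)c2c1=O` gives 13600 nM, a number within the usual scatter of that of compound 1, so no order between the two can be claimed. Compound 3 `O=C(O)CCCn1sc2ccccc2c1=O` gives 67000 nM, a higher number than compound 1 by a margin beyond the scatter.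

Compound 4 `CC(C)CNC(=O)Cn1sc2ccccc2c1=O` has not yet been measured. It differs from compound 1 in one place: isopropyl in place of pyridin-2-yl on a saturated chain carbon bound to an amide-type nitrogen. Among the compounds with values here, no measured pair in this set reports such a change, so there is no step to lean on. The three known values sit close together at the weak end, and the change removes a ring without touching the shared core. The step of a 1.3-fold higher number from compound 1 to compound 4 (0.12 log units; within the scatter) is therefore expected to be small, most likely none beyond the scatter, with a slight lean toward a higher number. For compound 4 the estimate in this assay is 20000 nM, with a likely range from 7000 nM to 60000 nM.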

Compound 4, half-maximal inhibitory concentration: 10700 nM
For compound 4 the middle estimate is 1.9-fold (0.27 log units) above the measured one, within the range that was stated.
By their numbers in this assay, from the lowest: compounds 4, 2 and 1 (each within the scatter of the next); then compound 3.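

Within the data shown here, the only step at this position, a 1.4-fold lower number from compound 1 to compound 4 (0.15 log units; within the scatter) in this assay, shows that (pyridin-2-yl)methyl can be exchanged for isobutyl on the amide-type nitrogen without a change that can be told from the scatter. In this one pair, therefore, neither the six-membered aromatic ring nor its hydrogen-bond acceptor is required for a number at this level. Nothing available explains why the two groups read alike.

On these data alone, whether an amine or a carboxylic acid at the end of this chain, or a longer chain such as n-hexyl, would move the number beyond the scatter remains open. As far as these compounds go, it is also open whether a phenyl ring, which has no ring nitrogen, would read like pyridin-2-yl or like isopropyl.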